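Replacing the methylpiperazine on the oxazolidinone side chain

The source may hold more compounds than are shown below. What is called first, only, known or untested is meant among the compounds shown, and "the series" means these compounds.

Within the data shown here, in an ADME assay on L02 cells (Homo sapiens) for cytotoxicity, read by MTT assay, with a stated time of 48 h (on this read-out higher numbers stand for weaker inhibition and lower numbers for stronger inhibition), compound 2 `CN1CCN(C[C@H]2CN(c3ccc(-n4cc(-c5ccccn5)cn4)c(F)c3)C(=O)O2)CC1` gives 70 ug/mL, the only number among the three measured values. Compound 1 `CN(CCC#N)C[C@H]1CN(c2ccc(-n3cc(-c4ccccn4)cn3)c(F)c2)C(=O)O1` returns a limit, > 400 ug/mL. Compound 3 `O=C1CSC(=O)N1C[C@H]1CN(c2ccc(-n3cc(-c4ccccn4)cn3)c(F)c2)C(=O)O1` likewise returns a limit, > 400 ug/mL. The two readable steps are an at least 5.7-fold lower number from compound 1 to compound 2 (0.75 log units; beyond the scatter) and an at least 5.7-fold higher number from compound 2 to compound 3 (0.75 log units; beyond the scatter), and the wider picture is the limit of > 400 ug/mL in this assay, at which 2 of the 3 values shown sit. Compound 4 `O=C(NC[C@H]1CN(c2ccc(-n3cc(-c4ccccn4)cn3)c(F)c2)C(=O)O1)C(F)F` carries ((difluoromethyl)carbonyl)amino in place of 4-methylpiperazin-1-yl on a saturated chain carbon bound to a saturated ring carbon. Both measured changes away from 4-methylpiperazin-1-yl at this position moved the number beyond the scatter toward weaker inhibition, so the step from compound 2 to compound 4 is expected to be of the same kind, a 5.7-fold higher number from compound 2 to compound 4 (0.76 log units; beyond the scatter). Compound 4 is therefore estimated at 400 ug/mL, within 150 ug/mL to 1000 ug/mL, with a good chance that this assay reports only a limit.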

Compound 4, half-maximal inhibitory concentration: > 400 ug/mL
Compound 4: only a limit was reported; the forecaster's own chance of this, stated with the estimate: 70%; the middle value lies on the limit itself.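

The step away from 4-methylpiperazin-1-yl now also holds for a group with no ring and a hydrogen-bond donor: ((difluoromethyl)carbonyl)amino gives an at least 5.7-fold higher number from compound 2 to compound 4 (0.75 log units; beyond the scatter). The value of compound 4 is itself a limit, and the steps from compound 1 and compound 3 to compound 4 cannot be read. Compound 2 remains the only one with a number: the limit of > 400 ug/mL in this assay, at which 3 of the 4 values shown sit.

Still open, going by these compounds, is whether the lower number follows the piperazine ring or its N-methyl group. A morpholine, a piperidine or an unsubstituted piperazine on this saturated chain carbon would separate the two.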